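Swapping methoxy for chloro on the sulfonyl-linked aryl ring

This account rests on a few compounds, and the source may have more. Where it says the series, first, only, none or still open, it means among the compounds named here.

Compound 1 `COc1ccc(S(=O)(=O)c2n[nH]c3cc(N4CCNCC4)ccc23)cc1` and compound 2 `CN1CCN(c2ccc3[nH]nc(S(=O)(=O)c4ccc(F)cc4)c3c2)CC1` share a core in which a substituted phenyl sulfonyl group sits on a fused bicyclic ring bearing a piperazine. In an assay on HeLa cells for displacement of a labelled ligand from 5-hydroxytryptamine receptor 6 (Homo sapiens) (on this read-out higher numbers stand for weaker inhibition and lower numbers for stronger inhibition), compound 1 gives 124 nM, the higher of the two numbers measured, while compound 2 gives 5.2 nM; the two differ in more than one place, so their values are noted without being traced to a single change. Compound 3 `O=S(=O)(c1ccc(Cl)cc1)c1n[nH]c2cc(N3CCNCC3)ccc12` is not yet measured. It differs from compound 1 in one place: chloro in place of methoxy on an aromatic carbon. Going by the values given here, with no single-change step measured, the expected step is modest, toward a lower number, and may not reach beyond the scatter: from compound 1 to compound 3 the estimated change is a 2.1-fold lower number from compound 1 to compound 3 (0.32 log units; beyond the scatter). Compound 3 is therefore expected to give about 60 nM in this assay, within a range of 20 nM to 200 nM.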

Compound 3, inhibition constant: 110 nM
Compound 3: middle estimate off by 1.8-fold (0.26 log units), on the low side, and the stated range covers the measured number.
By their numbers in this assay, from the lowest: compound 2; then compounds 3 and 1 (each within the scatter of the next).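

In this assay, putting chloro in place of methoxy on the aromatic carbon gives a 1.1-fold lower number from compound 1 to compound 3 (0.05 log units; within the scatter) and so separates 4-methoxyphenyl from 4-chlorophenyl by no measurable amount. Going by these compounds alone, this is the first single-change step, and it shows that at this place, para to a large group, exchanging a two-heavy-atom group that carries a hydrogen-bond acceptor for a single chlorine with none leaves the number within the usual scatter. Nothing measured here accounts for this result.

The compounds shown leave open whether a group of a different kind at this position, such as an amine, a carboxylic acid or a nitrile, would move the number beyond the scatter. They also leave open whether this flat step would hold on a core carrying other changes elsewhere.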